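Repeating a Small Methyl Step on a Second Core

The source may report more compounds than this note shows. Statements on the series, on what has been measured and on what is new or still open speak of the compounds shown alone.

Compound 1 `C/N=C(\S)NCCCCCn1nc(-c2ccccc2)ccc1=O` gives 35.3 mg/kg in a functional assay on the whole organism (stomach) with Rattus norvegicus as the target; on this read-out higher numbers stand for an effect only at larger amounts of compound and lower numbers for an effect already at smaller amounts. Compound 2 `CC/N=C(\S)NCCCCCn1nc(-c2ccccc2)ccc1=O` carries methyl in place of hydrogen on a saturated chain carbon bound to a double-bonded nitrogen and gives 51.8 mg/kg; the result is a 1.5-fold higher number from compound 1 to compound 2 (0.17 log units; within the scatter). Compound 3 `CC/N=C(/NC#N)NCCCn1nc(-c2ccccc2)ccc1=O` differs from compound 1 by a group of 8 heavy atoms (4 carbon, 4 nitrogen; no ring) in place of a group of 7 heavy atoms (4 carbon, 2 nitrogen, 1 sulfur; no ring), on a saturated chain carbon, three bonds along the chain from an aromatic nitrogen. In this assay compound 3 gives 78.3 mg/kg; there is a 2.2-fold higher number from compound 1 to compound 3 (0.35 log units; beyond the scatter), while there is a 1.5-fold higher number from compound 2 to compound 3 (0.18 log units; within the scatter). Compound 4 `CCC/N=C(/NC#N)NCCCn1nc(-c2ccccc2)ccc1=O` carries, relative to compound 3, (methyl in place of hydrogen on a saturated chain carbon, two bonds along the chain from a double-bonded nitrogen). This is the same kind of change as that from compound 1 to compound 2, though the place differs: there the carbon is bound to the double-bonded nitrogen, here it lies two bonds along the chain from it. Compound 4 is expected to take a step of a 1.3-fold higher number from compound 3 to compound 4 (0.11 log units; within the scatter) in this assay because the same kind of change gave a 1.5-fold higher number from compound 1 to compound 2 (0.17 log units; within the scatter). Compound 4 is therefore estimated at 100 mg/kg, with a range from 55 mg/kg to 180 mg/kg.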

Compound 4, dose for half-maximal effect: 100 mg/kg
The estimate for compound 4 equals the measured number at the digits printed; measured number inside the range.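

In this assay the new step reads a 1.3-fold higher number from compound 3 to compound 4 (0.11 log units; within the scatter). Set beside the earlier step, the added methyl gives a comparable result on both cores: the same change on two cores in this assay, a 1.5-fold higher number (0.17 log units; within the scatter) from compound 1 to compound 2 and a 1.3-fold higher number (0.11 log units; within the scatter) from compound 3 to compound 4, 1.1-fold (0.06 log units) apart, within the scatter of two such steps. Going by these compounds alone, since each step lies within the scatter, this shows only that the change made no distinguishable difference on either core; it does not show that the methyl has a real effect, and two pairs, with the methyl in different places, set no rule for other cores.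

The compounds shown leave open what a longer chain such as butyl would give in place of the ethyl or propyl group. They also leave open whether a phenyl group there would fit the same picture.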